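A few compounds are considered here, and "the series" means these few. Any claim that something is new, unique, unknown or untested is made for them only; others in the source may bear on it.

Measured in a functional assay on HEK293 cells with Glucose-dependent insulinotropic receptor (Homo sapiens) as the target, read by cAMP accumulation, with a stated time of 60 min; on this read-out lower numbers stand for smaller maximal responses and higher numbers for larger maximal responses:
compound 1 `CCCc1cnc(N2CCC(C3Cc4cc(C5=CCN(S(=O)(=O)CCCO)CC5)cc(F)c4O3)CC2)nc1` gives 92%
compound 2 `CCCc1cnc(N2CCC(C3Cc4cc(C5=CCN(S(=O)(=O)CCCCO)CC5)cc(F)c4O3)CC2)nc1` gives 98%
compound 3 `CCCc1cnc(N2CCC(C3(C)Cc4cc(C5=CCN(S(=O)(=O)CCCO)CC5)ccc4O3)CC2)nc1` gives 78%

Compound 3 stands lowest of the three; compound 1 and compound 2 lie within the scatter of each other. How the core of compound 3 differs from the core of compound 1 is not broken down here. The change from compound 1 to compound 2, (hydroxymethyl in place of hydroxy on a saturated chain carbon, three bonds along the chain from a sulfonyl sulfur), gave a number 6 percentage points higher from compound 1 to compound 2 (within the scatter). Compound 4 `CCCc1cnc(N2CCC(C3(C)Cc4cc(C5=CCN(S(=O)(=O)CCCCO)CC5)ccc4O3)CC2)nc1` is not yet measured in this assay; it arises from compound 3 by the same change, (hydroxymethyl in place of hydroxy on a saturated chain carbon, three bonds along the chain from a sulfonyl sulfur), at a place described in the same words. The expected step is small, a number 5 percentage points higher from compound 3 to compound 4 (within the scatter), and rests on a number 6 percentage points higher from compound 1 to compound 2 (within the scatter). For compound 4 the estimated value in this assay is 83%, with a range from 70% to 96%.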

Compound 4, largest response reached (Emax), in percent of the reference or control that the assay uses: 67%
Beside the measured number, compound 4's estimate is 16 percentage points above it; the measured number lies below the stated range.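

In this assay, hydroxymethyl in place of hydroxy on a saturated chain carbon, three bonds along the chain from a sulfonyl sulfur, gave a number 11 percentage points lower from compound 3 to compound 4 (beyond the scatter), so the change does not carry over unchanged between these two cores: the same change on two cores in this assay, a number 6 percentage points higher (within the scatter) from compound 1 to compound 2 and a number 11 percentage points lower (beyond the scatter) from compound 3 to compound 4, 17 percentage points apart, beyond the scatter of two such steps

For these two pairs, the step on one core is therefore a poor guide to the step on the other. This does not show which feature of the cores sets the two steps apart, or how the change would behave on a further core.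

Open, from the compounds shown here alone, is how each core responds to a longer chain, such as 3-hydroxypropyl in place of hydroxymethyl, at this place. Also open, going by these compounds, is the effect of an amine or a carboxylic acid in place of the hydroxy.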